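Amino to methoxy on compound 3

This account rests on a few compounds, and the source may have more. Where it says the series, first, only, none or still open, it means among the compounds named here.

Compound 1 `C=C1[C@@H](O)[C@H](n2cnc3c(Cl)nc(N)nc32)O[C@@H]1CO`: 441000 nM
Compound 2 `C=C1[C@@H](O)[C@H](n2cnc3c(OC)nc(N)nc32)O[C@@H]1CO`: 446000 nM
Compound 3 `C=C1[C@H](n2cnc3c(N)nc(N)nc32)O[C@H](CO)[C@H]1O`: 8200 nM

In a functional assay on L1210 cells (Mus musculus) for inhibition (a lower number here means a stronger inhibitor, a higher number a weaker inhibitor), compound 3 stands lowest of the three, beyond the scatter from both compound 1 and compound 2. Compound 4 `C=C1[C@H](n2cnc3c(OC)nc(N)nc32)O[C@H](CO)[C@H]1O` departs from compound 3 by one change, methoxy in place of amino on an aromatic carbon. Among the compounds with values here, no measured step replaces amino. The only one, a 1.0-fold higher number from compound 1 to compound 2 (0.00 log units; within the scatter), puts methoxy in place of chloro, so it bears only indirectly. Compound 2 carries the methoxy group at 446000 nM, yet it differs from compound 3 elsewhere too, so it gives only a loose guide. A moderate rise in the number is expected, and the estimated step is a 3.7-fold higher number from compound 3 to compound 4 (0.56 log units; beyond the scatter). For compound 4 the expected value is 30000 nM, within an estimated range of 4000 nM to 200000 nM.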

Compound 4, half-maximal inhibitory concentration: 10000 nM
Compound 4: middle estimate off by 3.0-fold (0.48 log units), on the high side, within the range that was stated.
By their numbers in this assay, from the lowest: compounds 3 and 4 (each within the scatter of the next); then compounds 1 and 2 (each within the scatter of the next).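

In this assay, methoxy in place of amino on an aromatic carbon is a 1.2-fold higher number from compound 3 to compound 4 (0.09 log units; within the scatter), so the two groups cannot be told apart at this position on the core of compound 3. The earlier step, a 1.0-fold higher number from compound 1 to compound 2 (0.00 log units; within the scatter), compared methoxy only with chloro, on a different core. The new step adds amino to the groups that stay within the scatter of methoxy, even though methoxy carries no hydrogen-bond donor. The compounds shown leave open whether a hydroxyl group or an ethoxy group here would also stay within the scatter. Nothing measured here explains this result.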